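The source may hold more compounds than are shown below. What is called first, only, known or untested is meant among the compounds shown, and "the series" means these compounds.

Measured in a functional assay, with a stated time of 30 min; on this read-out higher numbers stand for weaker inhibition and lower numbers for stronger inhibition:
compound 1 `O=C(/C=C/c1ccc(O)c(O)c1)CC(=O)/C=C/c1cccc(O)c1O`: 19000 nM
compound 2 `O=C(/C=C/c1ccccc1O)CC(=O)/C=C/c1cccc(O)c1O`: 23000 nM
compound 3 `O=C(/C=C/c1ccc(O)c(O)c1)CC(=O)/C=C/c1cc(O)ccc1O`: 60000 nM

Compound 3 gives the highest number of the three, which makes it the weakest inhibitor here. Compound 4 `O=C(/C=C/c1cccc(O)c1)CC(=O)/C=C/c1cc(O)ccc1O` differs from it as follows: hydrogen in place of hydroxy on an aromatic carbon. This hydrogen in place of hydroxy on an aromatic carbon turns the 3,4-dihydroxyphenyl group into 3-hydroxyphenyl. The closest parallel is compound 2, which also replaces the 3,4-dihydroxyphenyl group with a different hydroxyphenyl group, and that change gave a 1.2-fold higher number from compound 1 to compound 2 (0.08 log units; within the scatter). The other measured change, a 3.2-fold higher number from compound 1 to compound 3 (0.50 log units; beyond the scatter), concerns the group that compound 3 and compound 4 share, so it bears less on this question. Going by the values given here, with only one close comparison, no step beyond the scatter is expected in this assay. The expected change is a 1.1-fold higher number from compound 3 to compound 4 (0.03 log units; within the scatter). For compound 4 the estimated value is 65000 nM, with an expected range of 25000 nM to 160000 nM.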

Compound 4, half-maximal inhibitory concentration: 88000 nM
Beside the measured number, compound 4's estimate is 1.4-fold (0.13 log units) below it; low and high end bracket the measured number.
By their numbers in this assay, from the lowest: compounds 1 and 2 (each within the scatter of the next); then compounds 3 and 4 (each within the scatter of the next).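

In this assay, hydrogen in place of hydroxy on an aromatic carbon gives a 1.5-fold higher number from compound 3 to compound 4 (0.17 log units; within the scatter), so 3,4-dihydroxyphenyl and 3-hydroxyphenyl cannot be told apart here. Going by these compounds alone, this is the first comparison to isolate that one hydroxy group, and with the 2,5-dihydroxyphenyl group kept, the weak inhibition does not depend on it. No measurement at hand explains this result. Still open, from the compounds shown here alone, is whether a methoxy group or an amine in that place would give a step beyond the scatter. Going by these compounds, it is also open whether the same loss of hydroxy would read alike with a 2,3-dihydroxyphenyl group kept instead.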